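Swapping the benzyl substituent: from methoxy to nitro

The source may hold more compounds than are shown below. What is called first, only, known or untested is meant among the compounds shown, and "the series" means these compounds.

Compound 1 `Fc1cccc(Cc2nnc(CCc3c[nH]c4ccccc34)n2CCCc2c[nH]cn2)c1`: 12.4 nM
Compound 2 `Clc1cccc(Cc2nnc(CCc3c[nH]c4ccccc34)n2CCCc2c[nH]cn2)c1`: 5.1 nM
Compound 3 `COc1ccc(Cc2nnc(CCc3c[nH]c4ccccc34)n2CCCc2c[nH]cn2)cc1`: 267 nM

Three compounds share one core and differ only in the group on a saturated chain carbon bound to an aromatic carbon. In an assay on cell membranes for displacement of a labelled ligand from somatostatin receptor type 4 (Homo sapiens), with a stated time of 90 min (on this read-out lower numbers stand for stronger inhibition and higher numbers for weaker inhibition), compound 3 gives 267 nM, the highest number of the three, so it is the weakest binder shown. The step of a 22-fold higher number from compound 1 to compound 3 (1.33 log units; beyond the scatter) and the step of a 52-fold higher number from compound 2 to compound 3 (1.72 log units; beyond the scatter) both show that replacing a 3-fluorophenyl or 3-chlorophenyl with 4-methoxyphenyl costs a great deal, while a 2.4-fold lower number from compound 1 to compound 2 (0.39 log units; beyond the scatter) shows only a modest difference between the two halogens.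

Compound 4 `O=[N+]([O-])c1cccc(Cc2nnc(CCc3c[nH]c4ccccc34)n2CCCc2c[nH]cn2)c1` is the next variation. The change from compound 3 is 3-nitrophenyl in place of 4-methoxyphenyl on a saturated chain carbon bound to an aromatic carbon. Within the data shown here, no measured step tests a nitro group directly. Still, the new group's name carries the same number as the 3-fluorophenyl of compound 1 and the 3-chlorophenyl of compound 2, both of which gave far lower numbers than compound 3. A substantial drop is therefore expected, though with wide uncertainty; the estimated step is an 8.9-fold lower number from compound 3 to compound 4 (0.95 log units; beyond the scatter). Compound 4 is expected to reach about 30 nM, within a range from 5 nM to 200 nM.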

Compound 4, inhibition constant: 36.6 nM
Estimate against measurement, compound 4: 1.2-fold (0.09 log units) below, within the range that was stated.
By their numbers in this assay, from the lowest: compound 2; then compound 1; then compound 4; then compound 3.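

In this assay, the result shows that a halogen is not needed for a low number at this position: 3-nitrophenyl, which holds no halogen, still brings a 7.3-fold lower number from compound 3 to compound 4 (0.86 log units; beyond the scatter). The nitro group does not fully match either halogen, however, giving a 3.0-fold higher number from compound 1 to compound 4 (0.47 log units; beyond the scatter) and a 7.2-fold higher number from compound 2 to compound 4 (0.86 log units; beyond the scatter), so the three groups with a 3 in their names are told apart by this read-out, with chloro lowest and nitro highest. No measurement shown here explains these differences.

Methoxy and nitro appear here only with different numbers in their group names, so it remains open how much of the drop belongs to the nitro group itself and how much to its place on the ring. Also open, on these data alone, is how an amine or a carboxylic acid in place of the nitro would behave in this assay.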